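The source may hold more compounds than are shown below. What is called first, only, known or untested is meant among the compounds shown, and "the series" means these compounds.

Compound 1 `CNC(=O)c1cc(C(=O)NC2CC2)cn(Cc2cccc(C)c2)c1=O`: >= 205 ug/mL
Compound 2 `CNC(=O)c1cc(C(=O)NC2CC2)cn(CC2CCCOC2)c1=O`: >= 131 ug/mL
Compound 3 `CNC(=O)c1cc(C(=O)NC2CC2)cn(CC2CCOCC2)c1=O`: >= 165 ug/mL

In a physicochemical assay for solubility (a higher number here means a more soluble compound, a lower number a less soluble compound), compound 3 gives >= 165 ug/mL, which is a limit and not a number. The values of compound 1 and compound 2 are limits as well, so none of the three compounds has an exact reading.

Compound 4 `CNC(=O)c1cc(C(=O)NC2CC2)cn(Cc2cccc(C#N)c2)c1=O` has not yet been measured. It carries 3-cyanophenyl in place of oxan-4-yl on a saturated chain carbon bound to an aromatic nitrogen.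

Going by the values given here, three measured steps bear on this change: a step that the two limits leave unreadable from compound 1 to compound 3, a step that the two limits leave unreadable from compound 1 to compound 2 and a step that the two limits leave unreadable from compound 2 to compound 3. None of them gives a size. The closest guide is compound 1, which has 3-methylphenyl at that place and a six-membered aromatic ring of carbon only, and its >= 205 ug/mL is a limit. With no readable size to carry over, no step beyond the scatter is expected in this assay, and the expected change is a step that the limit leaves unreadable from compound 3 to compound 4. Compound 4 is estimated at 180 ug/mL, with an expected range of 80 ug/mL to 270 ug/mL, and it may well be reported as a limit too.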

Compound 4, solubility: >= 148 ug/mL
Compound 4 ended at the assay's limit; the forecaster's own chance of this, stated with the estimate: 70%; the middle value lies beyond the limit too.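

In this assay compound 4 gives >= 148 ug/mL, which is a limit and not a number. Going by these compounds alone, compound 1, compound 2 and compound 3 also carry only limits, so no step to compound 4 can be read. From the compounds shown here alone, the exact solubility of all four compounds, and any differences among them, remain open.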